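Swapping Methyl for Methoxy on the Shared Core

The compounds below may be only part of what the source reports. "The series", "measured", "known", "first", "only" and "open" are said of these compounds alone.

Three compounds have been measured in an assay on cells for inhibition of Amine oxidase [flavin-containing] B (Homo sapiens), read by fluorescence and Amplex Red, with a stated time of 15 min; on this read-out higher numbers stand for weaker inhibition and lower numbers for stronger inhibition:

Compound 1, `Cc1ccc2oc(=O)c(-c3ccc(Br)nn3)cc2c1`: 2160 nM
Compound 2, `Cc1ccc2cc(-c3ccc(Br)nn3)c(=O)oc2c1`: 750 nM
Compound 3, `Cc1cccc2cc(-c3ccc(Br)nn3)c(=O)oc12`: 2640 nM

Among these three, compound 2 gives the lowest number, 750 nM, and is therefore the most potent of the set. Compound 1 gives 2160 nM and compound 3 gives 2640 nM; both of these numbers lie above that of compound 2 by more than the usual scatter. All three carry the same methyl group, differing only in where it sits on the shared core.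

Compound 4, `COc1ccc2cc(-c3ccc(Br)nn3)c(=O)oc2c1`, has not yet been measured. It differs from compound 2 in one place: methoxy in place of methyl on an aromatic carbon. Going by the values given here, no measured pair shows the effect of this particular exchange, so the expectation rests on the small size of the change alone. The step is expected to be modest, a 1.1-fold higher number from compound 2 to compound 4 (0.05 log units; within the scatter), with no clear direction beyond the scatter. On that basis compound 4 is estimated to give 850 nM in this assay, within a range of 300 nM to 2400 nM.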

Compound 4, half-maximal inhibitory concentration: 3050 nM
Compound 4: the middle estimate sits 3.6-fold (0.55 log units) below what was measured, outside the stated range (above it).
By their numbers in this assay, from the lowest: compound 2; then compounds 1, 3 and 4 (each within the scatter of the next).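

In this assay, the exchange of methyl for methoxy at this aromatic carbon gives a 4.1-fold higher number from compound 2 to compound 4 (0.61 log units; beyond the scatter), so this position does not accept every small group alike. The earlier compounds shown here showed only what happens when the methyl group sits at different places on the shared core, whereas this pair keeps the place fixed and changes the group itself, adding a single oxygen atom to it. Nothing at hand gives a reason for this step.

As far as these compounds go, whether an ethyl group, a hydroxyl group or a fluorine atom on this same carbon would stay closer to compound 2 remains open. Also open, from the compounds shown here alone, is whether methoxy would bring a similar step at the places where the methyl group sits in compound 1 and in compound 3.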